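Adding an Allyloxy Group to Compound 1

The compounds below may be only part of what the source reports. "The series", "measured", "known", "first", "only" and "open" are said of these compounds alone.

Measured so far:
- compound 1, `Cc1ccccc1-c1n[nH]c(-c2ccccc2)n1` — in a functional assay on the whole organism (Cricetulus griseus) with Cricetinae gen. sp. as the target (on this read-out higher numbers stand for an effect only at larger amounts of compound and lower numbers for an effect already at smaller amounts), compound 1 gives 10 mg/kg
- compound 2, `Cc1cc(Cl)ccc1-c1n[nH]c(-c2ccccc2)n1` — in this assay compound 2 gives 4 mg/kg
- compound 3, `Cc1ccc(-c2n[nH]c(-c3ccccc3)n2)c(C)c1` — in this assay compound 3 gives > 5 mg/kg

The value given for compound 3 is a limit of the assay, not a number. Among the two real numbers, compound 1 has the higher one, and its nearest neighbour is compound 2: a 2.5-fold lower number from compound 1 to compound 2 (0.40 log units; beyond the scatter). The step that the limit leaves unreadable from compound 1 to compound 3 cannot be read, because the result for compound 3 sits at the limit of > 5 mg/kg in this assay, at which 1 of the 3 values shown sits.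

Compound 4, `C=CCOc1cccc(-c2nc(-c3ccccc3C)n[nH]2)c1`, differs from compound 1 in one place: allyloxy in place of hydrogen on an aromatic carbon. Among the measured compounds shown here, no measured step touches this ring or this group, so the two steps from compound 1 give only a loose guide: the chloro change was modest, the methyl change unreadable. A step of similar modest size in either direction, or none beyond the scatter, is therefore expected. The estimate for compound 4 is 7 mg/kg, within 3 mg/kg to 20 mg/kg, which is expected to mean a 1.4-fold lower number from compound 1 to compound 4 (0.15 log units; within the scatter).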

Compound 4, dose for half-maximal effect: 5 mg/kg
The estimate for compound 4 lay 1.4-fold (0.15 log units) above the measured number, and the stated range covers the measured number.
By their numbers in this assay, from the lowest: compounds 2, 4 and 1 (each within the scatter of the next, the first and the last beyond it).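

In this assay the allyloxy group brings a 2.0-fold lower number from compound 1 to compound 4 (0.30 log units; within the scatter) and so this change cannot be told apart from leaving the hydrogen in place. Among the compounds shown here, the earlier compounds varied only chloro and methyl groups elsewhere on the molecule, so compound 4 is the first to show that this aromatic carbon can carry a group, here one of 4 heavy atoms with an oxygen and a double bond, while the dose stays in the same range. Nothing among the measurements shown explains why this group leaves the number so close to that of compound 1.

Going by these compounds, whether a methoxy group, an amine or a carboxylic acid on this carbon would move the number beyond the scatter stays open. One group at one place also says nothing yet about the other carbons of this ring.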